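The compounds below may be only part of what the source reports. "The series", "measured", "known", "first", "only" and "open" are said of these compounds alone.

Three compounds of this set have been measured in an assay on membranes from CHO cells for displacement of a labelled ligand from adenosine receptor A1 (Homo sapiens), read by scintillation counting, with a stated time of 60 min, tested at 1 uM; on this read-out higher numbers stand for more inhibition at the one concentration tested (going by the name of the read-out) and lower numbers for less inhibition:

compound 1 `CC1=C(C(=O)C2CC2)C(c2ccco2)NC(=O)N1` – 2%
compound 2 `CC1=C(C(=O)CC(C)C)C(c2ccco2)NC(=O)N1` – 16%
compound 3 `CCC(C)OC(=O)C1=C(C)NC(=O)NC1c1ccco1` – 6%

All three share one core and differ only in the group on a carbonyl carbon. Compound 3 stands second highest of the three numbers, but neither neighbour is separated from it beyond the scatter: the step of a number 4 percentage points higher from compound 1 to compound 3 (within the scatter) is small, and so is a number 10 percentage points lower from compound 2 to compound 3 (within the scatter). For the measured compounds named here, the only step that exceeds the scatter is a number 14 percentage points higher from compound 1 to compound 2 (beyond the scatter), a modest rise.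

Compound 4 `CC1=C(C(=O)OC2CCCC2)C(c2ccco2)NC(=O)N1` is the next member. It differs from compound 3 by cyclopentyl in place of sec-butyl on an oxygen next to a carbonyl group. Going by the values given here, no measured step touches a cyclopentyl group on an oxygen next to a carbonyl group; the two steps that involve the sec-butoxy group, from compound 1 and from compound 2, both lie within the scatter, and the one clear step concerns the carbonyl carbon itself, not the oxygen. Compound 4 is therefore expected to show a step of a number 2 percentage points higher from compound 3 to compound 4 (within the scatter), that is nothing beyond the scatter, and its expected value is 8% within a range of 0% to 20%.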

Compound 4, a percentage reported as inhibition, at one concentration (the size of the read-out at that concentration, not a potency): 1%
Beside the measured number, compound 4's estimate is 7 percentage points above it; the measured number falls inside the stated range.
By their numbers in this assay, from the lowest: compounds 4, 1, 3 and 2 (each within the scatter of the next, the first and the last beyond it).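

In this assay, cyclopentyl in place of sec-butyl is the first change shown on an oxygen next to a carbonyl group, and it brings in a five-membered ring of carbon only, yet it gives a number 5 percentage points lower from compound 3 to compound 4 (within the scatter) and so no difference that can be read at this position. On a carbonyl carbon, cyclopentyloxy in place of cyclopropyl gives a number 1 percentage points lower from compound 1 to compound 4 (within the scatter) and likewise leaves no readable difference, whereas cyclopentyloxy in place of isobutyl gives a number 15 percentage points lower from compound 2 to compound 4 (beyond the scatter) and adds a second clear step at compound 2, though compound 2 remains within the scatter of compound 3. Nothing available explains these results.

The compounds shown leave open whether a longer chain on an oxygen next to a carbonyl group, or an amine on a carbonyl carbon, would move the number beyond the scatter. With a single tested concentration, they also leave potency at the receptor unresolved.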